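Swapping a tert-butoxy for a methyl on the amide-side aryl

The source may hold more compounds than are shown below. What is called first, only, known or untested is meant among the compounds shown, and "the series" means these compounds.

Measured so far:
Compound 1, `CCn1c(CNc2ccccc2)nnc1SCC(=O)Nc1ccccc1`, in an assay on isolated protein for inhibition of long-chain fatty acid transport protein 1 (Homo sapiens) (on this read-out higher numbers stand for weaker inhibition and lower numbers for stronger inhibition), compound 1 gives > 1000 nM, which is a limit of the assay and not a number.
Compound 2, `CCn1nnc(-c2ccc(NC(=O)CSc3nnc(CNc4ccccc4)n3CC)cc2)n1`, in this assay compound 2 gives > 1000 nM, again a limit.
Compound 3, `CCn1c(CNc2ccccc2)nnc1SCC(=O)Nc1ccc(C(=O)OC(C)(C)C)cc1`, in this assay compound 3 gives > 1000 nM, also a limit.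

Compound 3 therefore stands nowhere in particular on the numbers shown: all three values sit at the same limit, (the limit of > 1000 nM in this assay, at which 3 of the 3 values shown sit). From the compounds shown here alone, the steps among the measured compounds, from compound 1 to compound 2 a step that the two limits leave unreadable from compound 1 to compound 2, from compound 1 to compound 3 a step that the two limits leave unreadable from compound 1 to compound 3 and from compound 2 to compound 3 a step that the two limits leave unreadable from compound 2 to compound 3, cannot be read, so their sizes are unknown.

The unmeasured compound 4, `CCn1c(CNc2ccccc2)nnc1SCC(=O)Nc1ccc(C(C)=O)cc1`, differs from compound 3 only in methyl in place of tert-butoxy on a carbonyl carbon. Going by the values given here, none of the measured steps touches this group, and none carries a readable size, so no direction of change can be drawn from them. With every neighbour at the limit, the most likely outcome is that compound 4 also ends at the limit, though a real number cannot be ruled out.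

Compound 4 is expected to come out at about 3000 nM in this assay, within 700 nM to 30000 nM. The step expected from compound 3 to compound 4 is a step that the limit leaves unreadable from compound 3 to compound 4.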

Compound 4, half-maximal inhibitory concentration: > 1000 nM
Compound 4: no number, only a limit; the forecaster's own chance of this, stated with the estimate: 80%; the middle value does not contradict the limit.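

Compound 4 also ends at a limit of the assay and not at a number, so no step from compound 1, compound 2 or compound 3 to compound 4 can be read: the limit of > 1000 nM in this assay, at which 4 of the 4 values shown sit.

The compounds shown leave open how strongly any of them acts in this assay, and whether changing tert-butoxycarbonyl to acetyl alters this at all.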